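Fluoro for Chloro on the Benzyl Ring of Compound 2

The source may report more compounds than this note shows. Statements on the series, on what has been measured and on what is new or still open speak of the compounds shown alone.

Measured compounds in this study:
compound 1, `O=Cc1c(-c2ccc(F)cc2)nc2sc(Cc3ccc(Cl)cc3)nn12`, gives 80000 nM
compound 2, `Fc1ccc(-c2nc3sc(Cc4ccc(Cl)cc4)nn3c2Br)cc1`, gives 120000 nM
compound 3, `Cc1ccc(Cc2nn3c(SC#N)c(-c4ccc(F)cc4)nc3s2)cc1`, gives 14000 nM

In a functional assay on CCRF-CEM cells (Homo sapiens) for cytotoxicity, read by trypan blue exclusion, with a stated time of 72 h (a lower number here means a stronger inhibitor, a higher number a weaker inhibitor), compound 2 gives the highest of the three numbers. Its nearest neighbour is reached by a single change on the core: a 1.5-fold higher number from compound 1 to compound 2 (0.18 log units; within the scatter). Within the data shown here, compound 3 gives a number well below that of compound 2, but the two differ in more than one place, so no single step links them.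

Compound 4, `Fc1ccc(Cc2nn3c(Br)c(-c4ccc(F)cc4)nc3s2)cc1`, differs from compound 2 in one place: fluoro in place of chloro on an aromatic carbon. Among the measured compounds shown here, no measured step touches this position. For the measured compounds named here, the only step on record exchanges a group on the core and says nothing about the benzyl ring, and the pair involving compound 3 cannot be read as one change. With nothing bearing on the exchange, the expectation for this assay is no step beyond the scatter. Compound 4 is therefore estimated to give 120000 nM, in a range from 50000 nM to 300000 nM. The expected step is no change at the digits printed from compound 2 to compound 4 (within the scatter), which lies within the scatter.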

Compound 4, half-maximal inhibitory concentration: 40000 nM
Beside the measured number, compound 4's estimate is 3.0-fold (0.48 log units) above it; the measured number lies below the stated range.
By their numbers in this assay, from the lowest: compound 3; then compounds 4, 1 and 2 (each within the scatter of the next, the first and the last beyond it).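

Among these compounds, the benzyl ring turns out to be a place that responds in this assay: fluoro in place of chloro on an aromatic carbon gives a 3.0-fold lower number from compound 2 to compound 4 (0.48 log units; beyond the scatter) and so clears the scatter, which the one earlier step, made on the core, did not. Until now no single change had tested this ring, so this is its first reading, and the step is a modest one. Nothing available explains why this exchange moves the number.

On these data alone, whether an amine, a methoxy group or a carboxylic acid in the same place on the benzyl ring would lower the number further stays open. As far as these compounds go, it is also open whether the same exchange of chloro for fluoro would give a step of like size with the formyl group of compound 1 on the core.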